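The source may hold more compounds than are shown below. What is called first, only, known or untested is meant among the compounds shown, and "the series" means these compounds.

In a functional assay on HEL cells (Homo sapiens) (a lower number here means that less compound is tolerated, a higher number that more compound is tolerated), compound 1 `CCOC(=O)NC(=O)NC1=CS(=O)(=O)O[C@@]12[C@@H](CO[Si](C)(C)C(C)(C)C)O[C@@H](n1cc(C)c(=O)n(C)c1=O)[C@@H]2O[Si](C)(C)C(C)(C)C` gives 14000 nM and compound 2 `C=C(C)C(=O)NC(=O)NC1=CS(=O)(=O)O[C@@]12[C@@H](CO[Si](C)(C)C(C)(C)C)O[C@@H](n1cc(C)c(=O)n(C)c1=O)[C@@H]2O[Si](C)(C)C(C)(C)C` gives 1200 nM as measured values. Compound 3 `Cc1cn([C@@H]2O[C@H](CO[Si](C)(C)C(C)(C)C)[C@@]3(OS(=O)(=O)C=C3NCC(=O)OCc3ccccc3)[C@H]2O[Si](C)(C)C(C)(C)C)c(=O)n(C)c1=O` stands only at a limit, with > 200000 nM as that limit. Compound 4 `Cc1cn([C@@H]2O[C@H](CO[Si](C)(C)C(C)(C)C)[C@@]3(OS(=O)(=O)C=C3NCCC(=O)O)[C@H]2O[Si](C)(C)C(C)(C)C)c(=O)n(C)c1=O` carries carboxymethyl in place of benzyloxycarbonyl on a saturated chain carbon bound to an amine nitrogen. Among the measured compounds shown here, no measured step covers this change directly. The nearest are the large steps of an at least 14-fold higher number from compound 1 to compound 3 (1.15 log units; beyond the scatter) and an at least 160-fold higher number from compound 2 to compound 3 (2.22 log units; beyond the scatter) on the amine nitrogen, and like compound 3, compound 4 lacks the carbamoyl groups removed there. Expected in this assay is no shift beyond the scatter, an estimated at least 1.3-fold lower number from compound 3 to compound 4 (0.12 log units; that floor lies within the scatter) and nothing larger. Compound 4 is estimated at 150000 nM with an expected range from 50000 nM to 300000 nM overall, and another limit is quite possible.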

Compound 4, half-maximal cytotoxic concentration: 34000 nM
Compound 4: middle estimate off by 4.4-fold (0.64 log units), on the high side, outside the stated range (below it).
By their numbers in this assay, from the lowest: compound 2; then compound 1; then compound 4. At a limit, above all of these: compound 3.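

Without either carbamoyl group, the substituent on the amine nitrogen still moves the number in this assay, with carboxymethyl in place of benzyloxycarbonyl: an at least 5.8-fold lower number from compound 3 to compound 4 (0.76 log units; beyond the scatter). Compound 3 stands only at a limit: the limit of > 200000 nM in this assay, at which 1 of the 4 values shown sits. Against the carbamoyl compounds the gap is uneven, with a 28-fold higher number from compound 2 to compound 4 (1.45 log units; beyond the scatter) but only a 2.4-fold higher number from compound 1 to compound 4 (0.39 log units; beyond the scatter).

Compound 4 differs from compound 3 in both the end group and the chain, so the two remain unseparated. The methyl ester of the 2-carboxyethyl chain, or a carboxylic acid on a shorter chain, would separate them.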